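The source may report more compounds than this note shows. Statements on the series, on what has been measured and on what is new or still open speak of the compounds shown alone.

Series notes. In a functional assay on HeLa cells (Homo sapiens) for cytotoxicity, read by MTT assay, with a stated time of 72 h, tested at 1 uM (a lower number here means less inhibition of growth, a higher number more inhibition of growth at the concentration tested), compound 1 `Cc1ccnc(/C(N)=N/NC(=S)N2CCCC2)c1` gives 25.9%, compound 2 `Cc1ccnc(/C(N)=N/NC(=S)N2CCCCCC2)c1` gives 43.2% and compound 3 `N/C(=N\NC(=S)N1CCN(c2ccccn2)CC1)c1ccc(F)cn1` gives 22.5%. Compound 3 has the lowest of the three numbers; its gap to compound 1 lies within the scatter, while compound 2 stands beyond it. Compound 4 `Cc1cccc(/C(N)=N/NC(=S)N2CCN(c3ccccn3)CC2)n1` remains to be measured in this assay. It differs from compound 3 by 6-methylpyridin-2-yl in place of 5-fluoropyridin-2-yl on a carbon with a double bond to nitrogen. Among the measured compounds shown here, no measured pair shows this exchange at that carbon, so no size for it is known from the numbers; the expectation is a step of no more than the scatter, with no direction favoured. Compound 4 is therefore estimated at 27%, with a range from 15% to 42%. The expected step is a number 4.5 percentage points higher from compound 3 to compound 4 (within the scatter).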

Compound 4, percent growth inhibition at one concentration: 51.8%
The estimate for compound 4 lay 24.8 percentage points below the measured number, outside the stated range (above it).
By their numbers in this assay, from the lowest: compounds 3 and 1 (each within the scatter of the next); then compounds 2 and 4 (each within the scatter of the next).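

In this assay, 6-methylpyridin-2-yl in place of 5-fluoropyridin-2-yl on a carbon with a double bond to nitrogen gives a number 29.3 percentage points higher from compound 3 to compound 4 (beyond the scatter), so this position responds to an exchange between two groups of equal heavy-atom, donor and acceptor counts. No measurement shown bears on the reason for the step.

The exchange alters both the substituent and its place on the ring, and the compounds shown do not separate the two. From the compounds shown here alone, whether 5-methylpyridin-2-yl, 6-fluoropyridin-2-yl or plain pyridin-2-yl would follow compound 3 or compound 4 stays open.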